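Changing the Acyl Group in a Legumain Inhibitor Series

A few compounds are considered here, and "the series" means these few. Any claim that something is new, unique, unknown or untested is made for them only; others in the source may bear on it.

Of the compounds shown here, three have been measured in an assay on isolated protein for inhibition of legumain (Mus musculus), read by fluorescence, with stated times of 30 s and 2.5 h; a higher number here means a weaker inhibitor, a lower number a stronger inhibitor. Compound 1 `CCOC(=O)/C=C/C(=O)N(CC(N)=O)NC(=O)[C@@H]1CCCN1C(=O)[C@H]1CCCCN1C(C)=O` gives 638 nM, compound 2 `C/C=C(\NC(C)=O)C(=O)N1CCC[C@H]1C(=O)NN(CC(N)=O)C(=O)/C=C/C(=O)OCC` gives 141 nM, and compound 3 `CCOC(=O)C1OC1C(=O)N(CC(N)=O)NC(=O)[C@@H]1CCCN1C(=O)C1(NC(C)=O)CC1` gives 4.4 nM. Compound 2 thus sits second highest of the three: compound 1 is higher, with a 4.5-fold lower number from compound 1 to compound 2 (0.66 log units; beyond the scatter), while compound 3 lies far lower. Compound 4 `CCOC(=O)/C=C/C(=O)N(CC(N)=O)NC(=O)[C@@H]1CCCN1C(=O)c1ccc(CNC(C)=O)cc1` differs from compound 2 by a group of 11 heavy atoms (9 carbon, 1 nitrogen, 1 oxygen; one six-membered aromatic ring of carbon only) in place of a group of 7 heavy atoms (5 carbon, 1 nitrogen, 1 oxygen; no ring), on a carbonyl carbon. For the measured compounds named here, the only measured change at that same carbonyl carbon, a 4.5-fold lower number from compound 1 to compound 2 (0.66 log units; beyond the scatter), was modest, so only a modest step is expected here, a 1.1-fold higher number from compound 2 to compound 4 (0.03 log units; within the scatter), with the direction uncertain from the data. Compound 4 is therefore estimated at 150 nM in this assay, within a range of 40 nM to 600 nM.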

Compound 4, half-maximal inhibitory concentration: 267 nM
Compound 4: the middle estimate sits 1.8-fold (0.25 log units) below what was measured; the range from low to high includes it.
By their numbers in this assay, from the lowest: compound 3; then compounds 2 and 4 (each within the scatter of the next); then compound 1.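

In this assay, the carbonyl carbon bonded to the ring amide nitrogen accepts a 4-(acetamidomethyl)phenyl group, with its aromatic ring, in place of the open-chain group, and the step stays within the scatter: a 1.9-fold higher number from compound 2 to compound 4 (0.28 log units; within the scatter). Putting the same aromatic group in place of the group with a six-membered non-aromatic ring gives a 2.4-fold lower number from compound 1 to compound 4 (0.38 log units; beyond the scatter), which is a modest gain. No available data explain these differences. Still open, on these data alone, is how the number would respond if a simple amine or a carboxylic acid replaced the acetamide end of the 4-(acetamidomethyl)phenyl group.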